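Benzyl Added Again, on a Different Ring

The compounds below may be only part of what the source reports. "The series", "measured", "known", "first", "only" and "open" are said of these compounds alone.

Of the compounds shown here, three sharing a common core have been measured in an assay on cell membranes for displacement of a labelled ligand from adenosine receptor A1 (Rattus norvegicus), tested at 100 uM; a lower number here means less inhibition, a higher number more inhibition at the concentration tested (going by the name of the read-out). Compound 1 `CNC(=O)C1CCCC1n1cnc2c(N)ncnc21` gives 25%, compound 3 `CNC(=O)C1CCCC1n1cnc2c(NCc3ccccc3)ncnc21` gives 26%, and compound 2 `CNC(=O)C1CC=CC1n1cnc2c(N)ncnc21` gives 22%. Compound 2 thus shows the lowest of the three numbers, but the gap to compound 1 and the gap to compound 3 both fall within the scatter, so the three cannot be told apart in this assay.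

Compound 4 `CNC(=O)C1CC=CC1n1cnc2c(NCc3ccccc3)ncnc21` has not yet been measured. It differs from compound 2 by benzyl in place of hydrogen on a nitrogen on an aromatic ring. Going by the values given here, one measured step bears directly on this change: a number 1 percentage points higher from compound 1 to compound 3 (within the scatter). That step, made on the core of compound 1, left the read-out unmoved beyond the scatter. Among the compounds with values here, nothing in the set suggests the same change on compound 2 should behave otherwise, and no step among the measured compounds moves this assay beyond its scatter.

The step that is therefore expected, a number 1 percentage points higher from compound 2 to compound 4 (within the scatter), amounts to none beyond the scatter. Compound 4 is estimated at 23%, with a range from 13% to 33%.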

Compound 4, a percentage reported as inhibition, at one concentration (the size of the read-out at that concentration, not a potency): < 10%
Compound 4: no number, only a limit (the forecaster's own chance of this, stated with the estimate: 2%); at least 13 percentage points between middle value and limit.
By their numbers in this assay, from the lowest: compounds 2, 1 and 3 (each within the scatter of the next). At a limit, below all of these: compound 4.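

In this assay, benzyl in place of hydrogen on a nitrogen on an aromatic ring now gives a step that can be told from the scatter: a number at least 12 percentage points lower from compound 2 to compound 4 (beyond the scatter). It is the only step among the compounds shown that does so, which means that this position is not indifferent to the change on every core. Compound 4 has no number here, only a limit of the assay, < 10%, so the step has a known minimum size but no known full size, and the comparison with the earlier step stays incomplete: the same change on two cores in this assay, a number 1 percentage points higher (within the scatter) from compound 1 to compound 3 and a number at least 12 percentage points lower (beyond the scatter) from compound 2 to compound 4; the limit leaves it open whether they differ

The compounds shown leave open whether the fall on the core of compound 2 belongs to benzyl as a whole or to its aromatic ring, and a methyl or a cyclohexylmethyl group on the same nitrogen would be the kind of neighbour that could separate the two. They also leave open how a longer chain, such as phenethyl, or a benzyl group carrying a carboxylic acid would read in this assay on either core.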